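The source may report more compounds than this note shows. Statements on the series, on what has been measured and on what is new or still open speak of the compounds shown alone.

Compound 1 `O=C1CSC(c2cccc(Cl)c2)N1CCN1CCCCC1` gives 100% in an ADME assay on Vero cells (Chlorocebus sabaeus) for cytotoxicity, read by neutral red uptake, tested at 49 ug/mL; on this read-out higher numbers stand for a weaker effect at the one concentration tested and lower numbers for a stronger effect; compound 2 `O=C1CSC(c2ccc(O)cc2)N1CCN1CCCCC1` gives 96%; compound 3 `COc1ccccc1C1SCC(=O)N1CCN1CCCCC1` gives 100%.

Compound 3 stands level with compound 1 at the digits reported, the two together the highest of the three numbers, while compound 2 lies a step lower that is within the scatter. Compound 4 `O=C1CSC(c2ccccc2[N+](=O)[O-])N1CCN1CCCCC1` differs from compound 3 by nitro in place of methoxy on an aromatic carbon. Among the measured compounds shown here, the only measured step that bears on an exchange of the group on the aromatic ring is the one from compound 1 to compound 2, which gave a number 4 percentage points lower from compound 1 to compound 2 (within the scatter). On that basis no step beyond the scatter is expected for compound 4 in this assay, that is a number 1 percentage points lower from compound 3 to compound 4 (within the scatter). Compound 4 is therefore estimated at 99%, between 89% and 105%.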

Compound 4, a percentage reported as activity, at one concentration (the size of the read-out at that concentration, not a potency): 100%
Estimate against measurement, compound 4: 1 percentage points below; low and high end bracket the measured number.
By their numbers in this assay, from the lowest: compounds 2, 1, 3 and 4 (each within the scatter of the next).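

In this assay, nitro in place of methoxy on an aromatic carbon ortho to a large group gives no change at the digits printed from compound 3 to compound 4 (within the scatter). Among the compounds shown here, this is the first step that exchanges one group for another at this same place, and it shows that the two groups cannot be told apart on this read-out at the one concentration tested. No measurement on hand offers an explanation for this result. Whether an amine or a carboxylic acid at this place would also leave the read-out within the scatter remains open, and no step shown here lies beyond it.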